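A few compounds are considered here, and "the series" means these few. Any claim that something is new, unique, unknown or untested is made for them only; others in the source may bear on it.

Working notes on the series. Within the data shown here, in an ADME assay on microsomes from liver (Homo sapiens) for metabolic stability, with a stated time of 10 min (a lower number here means that less of the compound is left, a higher number that more of the compound is left), compound 1 (`CO[C@]1(C(=O)N2CC[C@](c3ccc(C(F)(C(F)(F)F)C(F)(F)F)cc3)(S(=O)(=O)c3ccc(F)cc3)C2)CC[C@H](C(=O)O)CC1`) gives 82%, the only number available so far. Compound 2 (`O=C(O)C12CCC(C(=O)N3CC[C@](c4ccc(C(F)(C(F)(F)F)C(F)(F)F)cc4)(S(=O)(=O)c4ccc(F)cc4)C3)(CC1)C2`) carries the entry "not determined" (no result reported), so it has no place on this scale and offers no starting value for a step. Compound 3 (`O=C([C@H]1CC[C@H](CO)CC1)N1CC[C@](c2ccc(C(F)(C(F)(F)F)C(F)(F)F)cc2)(S(=O)(=O)c2ccc(F)cc2)C1`) is still to be measured, and the change leading to it lies on a carbonyl carbon: a group of 8 heavy atoms (7 carbon, 1 oxygen; one six-membered non-aromatic ring of carbon only) in place of a group of 10 heavy atoms (8 carbon, 2 oxygen; 2 five-membered non-aromatic rings of carbon only), on a carbonyl carbon. Among the measured compounds shown here, no measured step in this assay informs this change, so its size cannot be read from the data. For the measured compounds named here, the only anchor is compound 1 at 82%, and against that value a moderate fall is expected, not far beyond the usual scatter and with wide uncertainty. For compound 3 the estimated value is 70%, with an expected range of 45% to 90%.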

Compound 3, percent of the compound remaining: 75%
Compound 3: middle estimate off by 5 percentage points, on the low side; measured number inside the range.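

this assay now holds a first readable step at this place, on a carbonyl carbon whose other neighbours are amide-type nitrogen in a ring: a number 7 percentage points lower from compound 1 to compound 3 (within the scatter) with 4-(hydroxymethyl)cyclohexyl in place of 4-carboxy-1-methoxycyclohexyl. Any step from compound 2 cannot be read, as compound 2 has no number. Nothing available bears on why compound 1 and compound 3 read alike.

The step exchanges the whole group, so the separate contributions of the carboxy, methoxy and hydroxymethyl parts stay unresolved. Also open, as far as these compounds go, is how a group carrying an amine or a primary amide in place of the hydroxymethyl, or a longer chain ending in a hydroxyl, would read at this place in this assay.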